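The source may report more compounds than this note shows. Statements on the series, on what has been measured and on what is new or still open speak of the compounds shown alone.

For the measured compounds named here, compound 2 `O=c1nc2oc(CCCCl)cc2cn1Cc1cn(Cc2ccccc2)nn1` stands at 75500 nM in a functional assay on SW-620 cells (Homo sapiens) for antiproliferative activity, read by MTT assay, with a stated time of 72 h (a higher number here means a weaker inhibitor, a lower number a stronger inhibitor), the only number so far. Compound 1 `O=c1nc2oc(CCCCl)cc2cn1Cc1cn(-c2ccccc2F)nn1` gives only a limit in this assay, > 100000 nM. Going by the values given here, the one measured step, an at least 1.3-fold lower number from compound 1 to compound 2 (0.12 log units; that floor lies within the scatter), is therefore a floor, and its true size is unknown because of the limit of > 100000 nM in this assay, at which 1 of the 2 values shown sits. Compound 3 `O=c1nc2oc(CCCCl)cc2cn1Cc1cn(-c2ccc(Cl)cc2)nn1` carries 4-chlorophenyl in place of benzyl on an aromatic nitrogen, returning from benzyl to an aryl group on the same nitrogen, though a different one from compound 1. The measured step suggests the number may rise again, by an unknown amount; compound 3 is expected near 95000 nM, between 35000 nM and 260000 nM, a step of a 1.3-fold higher number from compound 2 to compound 3 (0.10 log units; within the scatter).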

Compound 3, half-maximal inhibitory concentration: > 100000 nM
Compound 3: a limit, no number; the forecaster's own chance of this, stated with the estimate: 45%; at least 1.0-fold (0.02 log units) between middle value and limit.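

For the compounds shown here, compound 3 adds a second aryl group on this nitrogen that ends at a limit rather than a number in this assay, leaving benzyl the only group here with a readable value. The change to 4-chlorophenyl gives an at least 1.3-fold higher number from compound 2 to compound 3 (0.12 log units; that floor lies within the scatter), which is only a floor, so no order of benzyl and the aryl groups can be claimed. The pair of compound 1 and compound 3 cannot be read, because both stop at the same limit: the limit of > 100000 nM in this assay, at which 2 of the 3 values shown sit.

As far as these compounds go, whether phenethyl, a longer chain on this nitrogen, or an amine on its phenyl ring would give a readable number stays open.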